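A few compounds are considered here, and "the series" means these few. Any claim that something is new, unique, unknown or untested is made for them only; others in the source may bear on it.

Of the compounds shown here, three built on one shared core have been tested in a functional assay on PC-3 cells (Homo sapiens) for inhibition, read by MTT assay, with stated times of 18 h and 4 h; on this read-out higher numbers stand for weaker inhibition and lower numbers for stronger inhibition. Compound 1 `CCCOP(=O)(O)OCCSC(=S)N1CCCC1` returns only a limit of the assay, > 100000 nM, and not a number. Compound 3 `CCCCCCOP(=O)(O)OCCSC(=S)N1CCCCC1` likewise returns only the limit > 100000 nM. Going by the values given here, compound 2 `CCCCCCCCCCOP(=O)(O)OCCSC(=S)N1CCCC1` is the one compound with a measured number: in this assay compound 2 gives 56100 nM. Among the compounds with values here, the single step between measured compounds, an at least 1.7-fold lower number from compound 1 to compound 2 (0.25 log units; that floor lies within the scatter), is heptyl in place of hydrogen on a saturated chain carbon, three bonds along the chain from an oxygen on an unsaturated carbon, and its size is bounded by the limit of > 100000 nM in this assay, at which 2 of the 3 values shown sit.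

Compound 4 `CCCCCCCCCCOP(=O)(O)OCCSC(=S)N1CCN(C)CC1` differs from compound 2 in one place: 4-methylpiperazin-1-yl in place of pyrrolidin-1-yl on a thiocarbonyl carbon. Within the data shown here, no measured step touches this ring exchange. The lone step from compound 1 to compound 2 concerns the chain, and compound 3, which carries yet another ring on the thiocarbonyl carbon, also differs from compound 2 in its chain, so those two compounds cannot be read as a single step. With nothing measured bearing on it, no change beyond the scatter is expected from the ring exchange, so the step of a 1.1-fold higher number from compound 2 to compound 4 (0.03 log units; within the scatter) is estimated to be small. Compound 4 is therefore expected to give about 60000 nM in this assay, within a range from 20000 nM to 200000 nM, with a real chance that only a limit is returned.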

Compound 4, half-maximal inhibitory concentration: 80000 nM
For compound 4 the middle estimate is 1.3-fold (0.12 log units) below the measured one; the measured number falls inside the stated range.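

Going by these compounds alone, compound 2 and compound 4 carry the same chain, so this pair is the first to show the group on the thiocarbonyl carbon changing on its own. In this assay, replacing pyrrolidin-1-yl with 4-methylpiperazin-1-yl gives a 1.4-fold higher number from compound 2 to compound 4 (0.15 log units; within the scatter), so a five-membered non-aromatic ring with 1 hetero atom and 0 hydrogen-bond acceptors gives way to a six-membered non-aromatic ring with 2 hetero atoms and 1 hydrogen-bond acceptor with no change that can be told from repeat-measurement noise. Both ends of this step are measured numbers, which does not hold for every compound in the set: the limit of > 100000 nM in this assay, at which 2 of the 4 values shown sit.

The compounds shown leave open whether a different kind of group on the thiocarbonyl carbon, such as an open-chain diethylamino group or a ring bearing a carboxylic acid, would move the number beyond the scatter. Within the data shown here, they also leave open whether a longer chain, in place of the one shared by compound 2 and compound 4, would matter more than this ring exchange did.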